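Methoxy in Place of Iodine on the Shared Core

A few compounds are considered here, and "the series" means these few. Any claim that something is new, unique, unknown or untested is made for them only; others in the source may bear on it.

Of the compounds shown here, two built on a shared core have been tested in a functional assay on the whole organism for inhibition, with Rattus norvegicus as the target; a higher number here means that more compound is needed for the effect, a lower number that less compound is needed. Compound 1 `CC1CC/C(=N\Nc2cccc(Cl)c2)c2ncc(C(=O)O)c(=O)n21` carries a 3-chlorophenyl group on an amine nitrogen; in this assay compound 1 reaches only the assay limit, > 100 umol/kg, and not a number. Compound 2 `CC1CC/C(=N\Nc2ccc(I)cc2)c2ncc(C(=O)O)c(=O)n21` carries a 4-iodophenyl group at that position; in this assay compound 2 likewise reaches only a limit, > 1000 umol/kg, rather than a number. The change from one to the other, a step that the two limits leave unreadable from compound 1 to compound 2, therefore cannot be read as a step of any size, and the limit of > 100 umol/kg in this assay, at which 1 of the 2 values shown sits, together with the limit of > 1000 umol/kg in this assay, at which 1 of the 2 values shown sits, is all that is known of these two. Compound 3 `COc1ccc(N/N=C2\CCC(C)n3c2ncc(C(=O)O)c3=O)cc1` is the next compound to consider: methoxy in place of iodo on an aromatic carbon. Within the data shown here, no measured step bears on this change; both known values are limits, so neither direction nor size can be drawn from them. Compound 3 is therefore expected to sit near the region where the limits lie, and the step of a number no higher from compound 2 to compound 3 (the limit leaves the size open) is expected to be small in either direction. The estimate for compound 3 is 1000 umol/kg, within the range 100 umol/kg to 10000 umol/kg.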

Compound 3, dose for 50% inhibition: 7.6 umol/kg
Compound 3: middle estimate off by 130-fold (2.12 log units), on the high side, outside the stated range (below it).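

In this assay methoxy gives the first true number among these compounds, where iodo on the same aromatic carbon gave only a limit, so this single exchange is enough to bring a compound out of the limit region. Putting methoxy in place of iodo gives an at least 130-fold lower number from compound 2 to compound 3 (2.11 log units; beyond the scatter) and the wider exchange of 3-chlorophenyl for 4-methoxyphenyl gives an at least 13-fold lower number from compound 1 to compound 3 (1.11 log units; beyond the scatter) and both steps lie beyond the usual scatter of repeated measurements. These are smallest possible sizes and the true sizes stay unknown, because each step starts from a limit rather than a number, as with compound 2: the limit of > 1000 umol/kg in this assay, at which 1 of the 3 values shown sits.

What remains open is how much of this drop belongs to methoxy itself: the compounds shown include no ethoxy group, hydroxyl group or amine at this place, so it cannot be said whether a longer chain or a different attached atom would also give a low dose. The step between compound 1 and compound 2 also stays unreadable, since both of those values are limits and not numbers.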